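A few compounds are considered here, and "the series" means these few. Any claim that something is new, unique, unknown or untested is made for them only; others in the source may bear on it.

Compound 1 `C=C[C@@](C)(/C=C/c1ccc(OC)cc1)CCC=C(C)C` was tested in a functional assay on SEM cells (Homo sapiens) for cytotoxicity, with a stated time of 72 h; a higher number here means that more compound is needed for the effect, a lower number that less compound is needed. In this assay compound 1 gives > 36600 nM, which is a limit of the assay and not a number. Compound 2 `C=C[C@@](C)(/C=C/c1ccc(O)cc1)CCCO` in this assay gives > 36600 nM, likewise a limit. For the measured compounds named here, compound 1 thus stands at the limit of > 36600 nM in this assay, at which 2 of the 2 values shown sit, and no step between measured compounds can be drawn from these two values, since neither is a number. Compound 3 `C=C[C@@](C)(/C=C/c1ccc(Nc2ccc(Cl)c(F)c2)cc1)CCC=C(C)C` has not yet been measured. It differs from compound 1 in one place: (4-chloro-3-fluorophenyl)amino in place of methoxy on an aromatic carbon. Going by the values given here, with no measured step to lean on, the size of the change in this assay is uncertain, and a result that again sits at a limit is as plausible as a number. The expected step is an at least 2.4-fold lower number from compound 1 to compound 3 (0.38 log units; beyond the scatter), leaning toward less compound being needed. Compound 3 is estimated at 15000 nM, with a range from 2000 nM to 36600 nM.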

Compound 3, half-maximal effective concentration: > 36600 nM
Compound 3 ended at the assay's limit (the forecaster's own chance of this, stated with the estimate: 50%); at least 2.4-fold (0.38 log units) between middle value and limit.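

Compound 1 and compound 3 both end at a limit of this assay, not at a number, so no step between them can be read: the limit of > 36600 nM in this assay, at which 3 of the 3 values shown sit.

The compounds shown leave open whether (4-chloro-3-fluorophenyl)amino in place of methoxy changes the result at all, and where any of these compounds would give an actual number.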